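A Chlorobenzyl Amine Gives Way to a Dimethylmorpholine

The source may report more compounds than this note shows. Statements on the series, on what has been measured and on what is new or still open speak of the compounds shown alone.

Compound 2 `Cc1csc2cc([C@H](C)Nc3ncnc(N)c3C#N)c(-c3cccc(CN(C)CCCN(C)Cc4ccc(Cl)cc4)c3)c(=O)n12` gives 3.2 in a physicochemical assay for lipophilicity (a higher number here means a more lipophilic compound, a lower number a more polar compound), and stands highest of the three measured values. Compound 1 `Cc1csc2cc([C@H](C)Nc3ncnc(N)c3C#N)c(-c3cccc(CN(C)CCCCN(C)Cc4ccccc4)c3)c(=O)n12` lies next, giving 2.2, and compound 3 `Cc1csc2cc([C@H](C)Nc3ncnc(N)c3C#N)c(Cc3cccc(CN(C)C)c3)c(=O)n12` lies furthest away, giving 0.8. Compound 4 `Cc1csc2cc([C@H](C)Nc3ncnc(N)c3C#N)c(-c3cccc(CN(C)CCCCN4C[C@@H](C)O[C@@H](C)C4)c3)c(=O)n12` has not yet been measured; it differs from compound 2 in one place: (2,6-dimethylmorpholin-4-yl)methyl in place of (4-chlorobenzyl)(methyl)amino on a saturated chain carbon, three bonds along the chain from an amine nitrogen. Among the compounds with values here, the single measured step that touches this part of the molecule is a number 1.00 log units higher from compound 1 to compound 2 (beyond the scatter), where the chlorine-bearing benzyl group arrived. Compound 4 removes that group and its aromatic ring altogether, so the step is expected to run the other way, beyond the scatter, and to be of at least the same size; the gap between compound 3 and compound 2 shows how far this region can move. The step from compound 2 to compound 4 is thus expected to be a number 1.50 log units lower from compound 2 to compound 4 (beyond the scatter). Compound 4 is estimated at 1.7, with a range from 1.1 to 2.3.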

Compound 4, distribution coefficient: 1.5
Estimate against measurement, compound 4: 0.20 log units above; the range from low to high includes it.
By their numbers in this assay, from the lowest: compound 3; then compound 4; then compound 1; then compound 2.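

Within the data shown here, at the place three bonds along the chain from an amine nitrogen, the earlier compounds showed only a rise, and here the change from (4-chlorobenzyl)(methyl)amino to (2,6-dimethylmorpholin-4-yl)methyl gives a number 1.70 log units lower from compound 2 to compound 4 (beyond the scatter) in this assay for the first time in the downward direction. The fall does not depend on the chlorine alone: 2,6-dimethylmorpholin-4-yl in place of benzyl(methyl)amino, which holds no chlorine, gives a number 0.70 log units lower from compound 1 to compound 4 (beyond the scatter) in this assay as well. Both comparisons therefore point the same way, for one morpholine with two defined stereocentres.

Going by these compounds, whether a morpholine without its two methyl groups, a piperidine or a carboxylic acid on this chain would fall as far remains open. The results offer no measured account of why the number drops with this change.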